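Trifluoromethyl in place of chloro on compound 1

The source may hold more compounds than are shown below. What is called first, only, known or untested is meant among the compounds shown, and "the series" means these compounds.

In an ADME assay on the whole organism (plasma, strain Sprague-Dawley) for pharmacokinetics, with Rattus norvegicus as the target, with a stated time of 24 h, at a dose of 2 mg/kg by the intravenous route (a higher number here means more compound in the circulation at the dose given, a lower number less compound in the circulation), compound 1 `O=C(CC(c1ccccc1)c1ccccc1)N1CCN(C(c2ccccc2)c2cccc(Cl)c2)CC1` gives 793 ng.h/mL and compound 2 `O=C(NC(c1ccccc1)c1ccccc1)N1CCN(C(c2ccccc2)c2ccccc2)CC1` gives 1150 ng.h/mL. Going by the values given here, these two numbers lie within the scatter of each other, so compound 1 stands level with its only measured neighbour. Compound 3 `O=C(CC(c1ccccc1)c1ccccc1)N1CCN(C(c2ccccc2)c2cccc(C(F)(F)F)c2)CC1` keeps the core of compound 1 and carries trifluoromethyl in place of chloro on an aromatic carbon, meta to a large group: trifluoromethyl in place of chloro on an aromatic carbon. Among the compounds with values here, no measured pair shows this change, so no shift beyond the scatter is expected, and the estimated step is a 1.1-fold lower number from compound 1 to compound 3 (0.02 log units; within the scatter). In this assay the estimate for compound 3 is 750 ng.h/mL, within an expected range of 350 ng.h/mL to 1600 ng.h/mL.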

Compound 3, area under the concentration-time curve in the Rattus norvegicus assay: 762 ng.h/mL
Compound 3: the middle estimate sits 1.0-fold (0.01 log units) below what was measured; measured number inside the range.
By their numbers in the Rattus norvegicus assay, from the lowest: compounds 3, 1 and 2 (each within the scatter of the next).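

Going by these compounds alone, in the Rattus norvegicus assay this pair gives the first reading of the change at this position: there is a 1.0-fold lower number from compound 1 to compound 3 (0.02 log units; within the scatter), so trifluoromethyl in place of chloro on this aromatic carbon leaves the circulating amount level. The same change does separate the two compounds in a physicochemical assay for solubility, at pH 7.4 (on this read-out higher numbers stand for higher solubility and lower numbers for lower solubility), where compound 1 gives 0.37 ug/mL and compound 3 gives 0.14 ug/mL, and solubility falls: the measured solubility of compound 1, 0.37 ug/mL, and of compound 3, 0.14 ug/mL, a 2.6-fold lower number (0.42 log units; beyond the scatter).

On these data alone, what an amine or a carboxylic acid on this aromatic carbon would do in the Rattus norvegicus assay or in the physicochemical assay stays open. So does whether the same change would read alike on the core of compound 2.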